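Benzyl variation on a ring sulfonamide nitrogen: cytotoxicity

A few compounds are considered here, and "the series" means these few. Any claim that something is new, unique, unknown or untested is made for them only; others in the source may bear on it.

Compound 1 `O=C1c2sccc2NS(=O)(=O)N1Cc1ccccc1`: in an ADME assay on MT4 cells (Homo sapiens) for cytotoxicity, read by MTT assay, with a stated time of 4 days (on this read-out higher numbers stand for lower toxicity in this test and lower numbers for higher toxicity in this test), compound 1 gives 374000 nM.
Compound 2 `O=C1c2sccc2N(Cc2ccccc2Cl)S(=O)(=O)N1Cc1ccccc1`: in this assay compound 2 reaches only the limit of the test, > 298000 nM.
Compound 3 `O=C1c2sccc2N(Cc2cccc(Cl)c2)S(=O)(=O)N1Cc1ccccc1`: in this assay compound 3 likewise reaches only the limit of the test, > 298000 nM.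

Compound 3 therefore stands at the limit of this assay rather than at a number, and the limit of > 298000 nM in this assay, at which 2 of the 3 values shown sit, shows that two of the three values sit there. From the compounds shown here alone, the steps a step that the limit leaves unreadable from compound 1 to compound 2, a step that the limit leaves unreadable from compound 1 to compound 3 and a step that the two limits leave unreadable from compound 2 to compound 3 are all left unreadable by these limits, so their size is unknown. The change to compound 4 `O=C1c2sccc2N(Cc2ccc(Br)cc2)S(=O)(=O)N1Cc1ccccc1` is 4-bromophenyl in place of 3-chlorophenyl on a saturated chain carbon bound to a sulfonamide nitrogen in a ring. For the measured compounds named here, none of the measured steps can be read in size, so they give no direction for this change; all that the three values show is that no compound has yet fallen clearly short of the limit in this assay. Compound 4 is accordingly expected to sit at or near the same limit, with the step that the limit leaves unreadable from compound 3 to compound 4 expected to be none beyond the scatter. The estimate for compound 4 in this assay is 350000 nM, in the range 200000 nM to 700000 nM.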

Compound 4, half-maximal cytotoxic concentration: 6600 nM
The estimate for compound 4 lay 53-fold (1.72 log units) above the measured number, outside the stated range (below it).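

In this assay, the group on this saturated chain carbon proves able to shift the read-out strongly towards higher toxicity in this test: 4-bromophenyl in place of 3-chlorophenyl gives an at least 45-fold lower number from compound 3 to compound 4 (1.65 log units; beyond the scatter), and in place of 2-chlorophenyl it gives an at least 45-fold lower number from compound 2 to compound 4 (1.65 log units; beyond the scatter). Adding a substituted benzyl group to the sulfonamide nitrogen does not by itself bring such a drop, since compound 2 and compound 3 stay at a limit, whereas the 4-bromobenzyl group gives a 57-fold lower number from compound 1 to compound 4 (1.75 log units; beyond the scatter). Compound 4 is thus the only compound shown with a number clearly short of that limit: the limit of > 298000 nM in this assay, at which 2 of the 4 values shown sit.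

From the compounds shown here alone, this change alters both the halogen and its place on the ring, so it remains open which of the two goes with the lower number. Going by these compounds, a 4-chlorophenyl or a 3-bromophenyl group would separate them, and how a 4-methoxyphenyl group would read also remains open.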